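The compounds below may be only part of what the source reports. "The series", "measured", "known", "first", "only" and "open" are said of these compounds alone.

In a functional assay on KB 3-1 cells (Homo sapiens) for antiproliferative activity, read by MTT assay, with a stated time of 72 h (a lower number here means a stronger inhibitor of growth, a higher number a weaker inhibitor of growth), compound 1 `Cc1c(C(=O)Nc2ccc(SC#N)cc2)nnn1-c1ccc(C(C)C)cc1` gives 7400 nM and compound 2 `Cc1ccc(Cl)cc1-n1nnc(C(=O)Nc2ccc(SC#N)cc2)c1C` gives 7800 nM, a pair separated only by a 1.1-fold higher number from compound 1 to compound 2 (0.02 log units; within the scatter). Compound 3 `Cc1ccc(Cl)c(-n2nnc(C(=O)Nc3ccc(SC#N)cc3)c2C)c1` gives 68000 nM, the highest number of the three, and it stands apart through an 8.7-fold higher number from compound 2 to compound 3 (0.94 log units; beyond the scatter) and a 9.2-fold higher number from compound 1 to compound 3 (0.96 log units; beyond the scatter). Compound 4 `COc1cccc(-n2nnc(C(=O)Nc3ccc(SC#N)cc3)c2C)c1` is compound 3 with one change on the aromatic nitrogen: 3-methoxyphenyl in place of 2-chloro-5-methylphenyl on an aromatic nitrogen. These three steps all replace the group at that same place, and they show that it can shift the number by a modest amount or by none beyond the scatter. Compound 3 sits at the high end, so a modest move toward lower numbers is expected. The estimated step is a 3.8-fold lower number from compound 3 to compound 4 (0.58 log units; beyond the scatter). The estimate for compound 4 is 18000 nM, with an expected range from 6000 nM to 60000 nM.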

Compound 4, concentration for 50% growth inhibition: > 100000 nM
Compound 4 ended at the assay's limit; the forecaster's own chance of this, stated with the estimate: 10%; at least 5.5-fold (0.74 log units) between middle value and limit.
By their numbers in this assay, from the lowest: compounds 1 and 2 (each within the scatter of the next); then compound 3. At a limit, above all of these: compound 4.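

In this assay compound 4 ended at a limit of the assay, not at a number: the limit of > 100000 nM in this assay, at which 1 of the 4 values shown sits. Among the compounds shown here, the steps from the two best-placed groups are large, an at least 12-fold higher number from compound 2 to compound 4 (1.10 log units; beyond the scatter) and an at least 13-fold higher number from compound 1 to compound 4 (1.13 log units; beyond the scatter), so 3-methoxyphenyl at this position gives up the growth inhibition that 5-chloro-2-methylphenyl and 4-isopropylphenyl keep, a wider span than the earlier compounds showed. Against compound 3 only a floor can be read, an at least 1.4-fold higher number from compound 3 to compound 4 (0.16 log units; that floor lies within the scatter), which leaves the order of that pair unsettled. As far as these compounds go, how an amine or a carboxylic acid in place of the methoxy group would read stays open.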